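The source may report more compounds than this note shows. Statements on the series, on what has been measured and on what is new or still open speak of the compounds shown alone.

Working notes on the ester series built on the shared core. In a functional assay on U-251 cells (Homo sapiens) for antiproliferative activity, read by sulforhodamine B assay, with a stated time of 48 h, tested at 50 uM (a higher number here means more inhibition at the concentration tested (going by the name of the read-out), a lower number less inhibition), compound 3 `CC1=CC[C@H](C(C)C)c2cc(C)c(OC(=O)c3cccc(C)c3)cc21` gives 16.8%. Compound 2 `CC1=CC[C@H](C(C)C)c2cc(C)c(OC(=O)c3ccc(C(F)(F)F)cc3)cc21` gives 14.7%, a figure that lies within the scatter of the figure for compound 3, so no order between these two is claimed. Compound 1 `COc1cccc(C(=O)Oc2cc3c(cc2C)[C@@H](C(C)C)CC=C3C)c1` is reported as "not active" (no number reported), without a number. Compound 4 `COc1ccc(C(=O)Oc2cc3c(cc2C)[C@@H](C(C)C)CC=C3C)cc1` is not yet measured; the change from compound 3 to compound 4 is 4-methoxyphenyl in place of 3-methylphenyl on a carbonyl carbon. Among the compounds with values here, no step between two measured compounds covers a change of this kind, and all figures so far sit low. A step from compound 3 to compound 4 of a number 5.8 percentage points lower from compound 3 to compound 4 (within the scatter) is expected, small and not beyond the scatter. Compound 4 is estimated at 11%, within a range of 0% to 25%.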

Compound 4, a percentage reported as inhibition, at one concentration (the size of the read-out at that concentration, not a potency): 37%
Compound 4: the middle estimate sits 26 percentage points below what was measured; measured number outside the range, above it.
By their numbers in this assay, from the lowest: compounds 2 and 3 (each within the scatter of the next); then compound 4.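

On the carbonyl carbon, the aryl group can move the read-out in this assay beyond the scatter, with a number 20.2 percentage points higher from compound 3 to compound 4 (beyond the scatter) and a number 22.3 percentage points higher from compound 2 to compound 4 (beyond the scatter) as the steps that show it. The 4-methoxyphenyl ester therefore stands apart from the two esters with numbers, although this rests on a single concentration. No measurement at hand bears on the cause of these steps. As far as these compounds go, whether an amine or a carboxylic acid on this aromatic ring would give a higher number remains open. Potency also remains open, as does any step involving compound 1, which has no number.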